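A carbamate swap on the shared piperazine core

The source may hold more compounds than are shown below. What is called first, only, known or untested is meant among the compounds shown, and "the series" means these compounds.

Among the measured compounds shown here, compound 2 `COc1cc(C(=O)N2CCN(C(=O)c3cc(OC)c(OC)c(OC)c3)C(COC(=O)NCCC(C)C)C2)cc(OC)c1OC` is the stronger of the two compounds measured so far: in a functional assay (Oryctolagus cuniculus) for inhibition of platelet-activating factor receptor (Cavia porcellus) (a lower number here means a stronger inhibitor, a higher number a weaker inhibitor), compound 2 gives 140 nM. For the measured compounds named here, its only neighbour is compound 1 `CCCCCCCCCC(=O)OCC1CN(C(=O)c2cc(OC)c(OC)c(OC)c2)CCN1C(=O)c1cc(OC)c(OC)c(OC)c1`, which in this assay gives 2820 nM. Going by the values given here, the one step that connects them is a 20-fold lower number from compound 1 to compound 2 (1.30 log units; beyond the scatter), a change that exchanges a nonyl chain for isopentylamino on a carbonyl carbon.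

Compound 3 `CCCN(CCC)C(=O)OCC1CN(C(=O)c2cc(OC)c(OC)c(OC)c2)CCN1C(=O)c1cc(OC)c(OC)c(OC)c1` is not yet measured. It differs from compound 2 by dipropylamino in place of isopentylamino on a carbonyl carbon. Among the compounds with values here, no measured step covers this kind of exchange: the only step available replaces a carbon chain with an amino group, whereas here one amino group replaces another and the carbonyl carbon keeps its oxygen neighbour. Because compound 1 and compound 2 lie so far apart in a 20-fold lower number from compound 1 to compound 2 (1.30 log units; beyond the scatter), this region is known to respond strongly to changes at that position, but the direction for compound 3 cannot be read from a single step. Compound 3 is therefore expected to stay fairly close to compound 2, with an estimated step of a 2.5-fold higher number from compound 2 to compound 3 (0.40 log units; beyond the scatter) and an estimated value of 350 nM, within a range from 70 nM to 1800 nM.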

Compound 3, half-maximal inhibitory concentration: 380 nM
Beside the measured number, compound 3's estimate is 1.1-fold (0.04 log units) below it; low and high end bracket the measured number.
By their numbers in this assay, from the lowest: compound 2; then compound 3; then compound 1.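

In this assay, a 2.7-fold higher number from compound 2 to compound 3 (0.43 log units; beyond the scatter), so exchanging one amino group for another on this carbonyl carbon does shift the number, though by less than the earlier step away from nonyl. Isopentylamino carries a hydrogen-bond donor and dipropylamino carries none, yet a 7.4-fold lower number from compound 1 to compound 3 (0.87 log units; beyond the scatter), so both amino groups shown give a lower number than nonyl, with or without that donor. The exchange also alters the heavy-atom count and the shape of the chains, so the rise from compound 2 to compound 3 cannot be assigned to the lost donor alone, and nothing measured here explains it.

The compounds shown leave open how much of the gain over compound 1 comes from the amino nitrogen and how much from the shorter chains, a question that an isopentyl group placed directly on the carbonyl carbon could help to settle. They also leave open whether a propylamino group, which keeps the amino hydrogen and a single propyl chain, or a ring amine such as piperidine would sit closer to compound 2 or to compound 3.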